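Benzyl for Cyclohexyl: Expected Shift in Calcium Channel Inhibition

The compounds below may be only part of what the source reports. "The series", "measured", "known", "first", "only" and "open" are said of these compounds alone.

Compound 1 `CCCOC(=O)C1=C(C)NC(C)=C(C(=O)OCC)C1c1csc(-c2ccc(Cl)cc2)n1` gives 4090 nM.
Compound 2 `CCOC(=O)C1=C(C)NC(C)=C(C(=O)OC2CCCCC2)C1c1csc(-c2ccc(Cl)cc2)n1` gives 100000 nM.

Both compounds were tested in an assay on isolated protein for antagonist activity at Voltage-dependent L-type calcium channel subunit alpha-1C (Cavia porcellus), with a stated time of 15 min; a lower number here means a stronger inhibitor, a higher number a weaker inhibitor. Going by the values given here, compound 2 stands at the highest of the two numbers; its only neighbour is compound 1, and the step between them, a 24-fold higher number from compound 1 to compound 2 (1.39 log units; beyond the scatter), is large and well beyond the scatter. Compound 3 `CCOC(=O)C1=C(C)NC(C)=C(C(=O)OCc2ccccc2)C1c1csc(-c2ccc(Cl)cc2)n1` has not yet been measured. It differs from compound 2 in one place: benzyl in place of cyclohexyl on an oxygen next to a carbonyl group. Among the compounds with values here, the single measured step that bears on this position is a 24-fold higher number from compound 1 to compound 2 (1.39 log units; beyond the scatter), which shows that the group on this oxygen can move the number a great deal. Benzyl is a third group, so the measured pair does not fix its number; yet because compound 2 already sits at the weakest value shown (100000 nM), a change at this place is more likely to lower the number than to raise it. Compound 3 is therefore expected to give 15000 nM, with a range from 3000 nM to 100000 nM. That estimate means an expected step of a 6.7-fold lower number from compound 2 to compound 3 (0.82 log units; beyond the scatter).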

Compound 3, half-maximal inhibitory concentration: 3290 nM
The estimate for compound 3 lay 4.6-fold (0.66 log units) above the measured number; low and high end bracket the measured number.
By their numbers in this assay, from the lowest: compounds 3 and 1 (each within the scatter of the next); then compound 2.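

In this assay, a six-membered ring on this oxygen does not by itself go with a high number, since benzyl in place of cyclohexyl gives a 30-fold lower number from compound 2 to compound 3 (1.48 log units; beyond the scatter). Cyclohexyl has a non-aromatic ring of 6 carbons, while benzyl has an aromatic ring and 7 carbons in all, and this single swap changes both the ring type and the carbon count, so the result cannot show which of the two differences matters. Propyl and benzyl, by contrast, cannot be told apart in this assay, as phenyl in place of ethyl on the saturated chain carbon gives only a 1.2-fold lower number from compound 1 to compound 3 (0.09 log units; within the scatter), and no measurement shown here explains why cyclohexyl stands apart from these two groups.

The compounds shown leave open how other groups on this oxygen would fall, such as a cyclopentyl ring, a longer chain like hexyl, or a chain ending in an amine. Going by these compounds, they all share the rest of the core as well, so whether benzyl in place of cyclohexyl would give a step of this size on a different core remains unknown.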